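The compounds below may be only part of what the source reports. "The series", "measured", "known", "first", "only" and "open" are said of these compounds alone.

Compound 1 `CC(C)[C@H](NC(=O)COc1cccc2ccccc12)C(=O)N[C@@H](CC(=O)O)C(=O)COC(=O)c1c(Cl)cccc1Cl` gives 11500 nM
Compound 2 `CC(C)[C@H](NC(=O)COc1cccc2ccccc12)C(=O)N[C@@H](CC(=O)O)C(=O)COc1ccc2ccccc2c1` gives 15900 nM
Compound 3 `CC(C)[C@H](NC(=O)COc1cccc2ccccc12)C(=O)N[C@@H](CC(=O)O)C(=O)COc1ccccc1[N+](=O)[O-]` gives 27700 nM

In a functional assay with Homo sapiens as the target (on this read-out higher numbers stand for weaker inhibition and lower numbers for stronger inhibition), compound 3 stands at 27700 nM and the steps reaching it are a 1.7-fold higher number from compound 2 to compound 3 (0.24 log units; within the scatter) and a 2.4-fold higher number from compound 1 to compound 3 (0.38 log units; beyond the scatter) in turn. Compound 4 (`CC(C)[C@H](NC(=O)COc1cccc2ccccc12)C(=O)N[C@@H](CC(=O)O)C(=O)COc1ccc([N+](=O)[O-])cc1`) differs from compound 3 by one change (4-nitrophenyl in place of 2-nitrophenyl on an oxygen on a saturated carbon) with 4-nitrophenyl in place of 2-nitrophenyl on an oxygen on a saturated carbon. For the measured compounds named here, no measured step makes this exact swap. The nearest evidence is whole-group replacement at that place, such as a 1.4-fold higher number from compound 1 to compound 2 (0.14 log units; within the scatter) and the two steps above, and all of these stay small. No step beyond the scatter is therefore expected in this assay in either direction. The expected step is a 1.4-fold lower number from compound 3 to compound 4 (0.14 log units; within the scatter) and no more. Compound 4 is estimated at 20000 nM with an expected range from 9000 nM to 42000 nM on this read-out.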

Compound 4, half-maximal inhibitory concentration: 22800 nM
The estimate for compound 4 lay 1.1-fold (0.06 log units) below the measured number; the measured number falls inside the stated range.
By their numbers in this assay, from the lowest: compounds 1, 2, 4 and 3 (each within the scatter of the next, the first and the last beyond it).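

In this assay, 4-nitrophenyl in place of 2-nitrophenyl gives a 1.2-fold lower number from compound 3 to compound 4 (0.08 log units; within the scatter), so exchanging these two groups with the same atoms shows no change on this oxygen. Naphthalen-2-yl replaced by 4-nitrophenyl gives a 1.4-fold higher number from compound 2 to compound 4 (0.16 log units; within the scatter), and (2,6-dichlorophenyl)carbonyl replaced by it gives a 2.0-fold higher number from compound 1 to compound 4 (0.30 log units; within the scatter), which leaves compound 4 within the scatter of all three other compounds, whereas compound 3 is not within the scatter of compound 1. No measurement at hand accounts for these results. From the compounds shown here alone, whether a phenyl ring bearing an amine or a carboxylic acid instead of the nitro group, or a longer chain on this oxygen, would move the number beyond the scatter remains open.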